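Spiro-fused series: replacing isopropyl with trifluoromethyl-tetrazolyl

The source may hold more compounds than are shown below. What is called first, only, known or untested is meant among the compounds shown, and "the series" means these compounds.

Working notes on three measured members of the series and one open position. Compound 1 `Fc1ccc([C@@H]2NCCOC23COC[C@H](c2ccccc2)C3)cc1` and compound 2 `c1ccc(C2CCC3(OCCNC3c3ccccc3)OC2)cc1` carry the shared core; in an assay on CHO cells for displacement of a labelled ligand from Substance-P receptor (Homo sapiens) (on this read-out higher numbers stand for weaker inhibition and lower numbers for stronger inhibition), compound 1 gives 99 nM and compound 2 gives 170 nM. Compound 3 `COc1ccc(C(C)C)cc1[C@H]1COCC2(C1)OCCN[C@H]2c1ccc(F)cc1` adds a methoxy and an isopropyl group to the aryl ring on the core; in this assay compound 3 gives 2.8 nM, the lowest of the three numbers, with compound 1 the nearest and compound 2 the furthest, both gaps beyond the scatter.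

Compound 4 `COc1ccc(-n2nnnc2C(F)(F)F)cc1[C@H]1COCC2(C1)OCCN[C@H]2c1ccc(F)cc1` differs from compound 3 in one place: 5-(trifluoromethyl)-1H-tetrazol-1-yl in place of isopropyl on an aromatic carbon, meta to a large group and para to the methoxy group. Among the measured compounds shown here, no measured pair in this set shows this kind of exchange, so the only anchor is the value of compound 3. The substituted aryl ring of compound 3 already sets the low end of the series; the new group keeps the methoxy group and the stereochemistry unchanged. A step of modest size in either direction, likely within or near the scatter, is expected for a 1.1-fold lower number from compound 3 to compound 4 (0.05 log units; within the scatter). Compound 4 is therefore estimated at 2.5 nM, with a range from 0.6 nM to 10 nM.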

Compound 4, half-maximal inhibitory concentration: 0.1 nM
Estimate against measurement, compound 4: 25-fold (1.40 log units) above; measured number outside the range, below it.
By their numbers in this assay, from the lowest: compound 4; then compound 3; then compounds 1 and 2 (each within the scatter of the next).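

In this assay, among the compounds shown here, 5-(trifluoromethyl)-1H-tetrazol-1-yl in place of isopropyl gives a 28-fold lower number from compound 3 to compound 4 (1.45 log units; beyond the scatter) and so supplies the first one-place exchange in this set. The aromatic carbon para to a methoxy group is therefore not limited to isopropyl: it accepts a much larger aromatic ring with no hydrogen-bond donors, and the exchange moves the read-out by a large step rather than leaving it within the scatter. No measurement at hand accounts for the size of this step or assigns it to any feature of the entering group.

For the compounds shown here, with only one exchange at this position, the contributions of the tetrazole ring and its trifluoromethyl group cannot be separated; the same tetrazole ring bearing a methyl group, or a trifluoromethyl group placed directly on the aromatic carbon, would address that question. On these data alone, it also remains open how this position responds to a different kind of group, such as an amine, a carboxylic acid or a longer alkyl chain, and whether the step carries over to other substitution patterns on the shared core.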